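The source may report more compounds than this note shows. Statements on the series, on what has been measured and on what is new or still open speak of the compounds shown alone.

Working notes on the series. The shared core is that of compound 1 `COc1cc2c(Oc3ccc(NC(=O)c4nnn(-c5ccccc5)c4C)cc3F)ccnc2cc1OCCCN1CCCC1`, which in a functional assay on NCI-H460 cells (Homo sapiens) for cytotoxicity, read by MTT assay, with a stated time of 72 h (on this read-out lower numbers stand for stronger inhibition and higher numbers for weaker inhibition), gives 160 nM. Compound 2 `COc1cc2c(Oc3ccc(NC(=O)c4nnn(-c5ccccc5)c4C)cc3F)ccnc2cc1OCCCN1CCCCC1` gives 220 nM in this assay; the step of a 1.4-fold higher number from compound 1 to compound 2 (0.14 log units; within the scatter) is within the scatter. Compound 3 `COc1cc2c(Oc3ccc(NC(=O)c4nnn(-c5ccccc5C)c4C)cc3F)ccnc2cc1OCCCN1CCC(C)CC1` gives 770 nM, the highest of the three numbers, beyond the scatter from both compound 1 and compound 2. Within the data shown here, compound 3 differs from compound 2 in two places at once, so no single measured step separates them.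

Compound 4 `COc1cc2c(Oc3ccc(NC(=O)c4nnn(-c5ccccc5)c4C)cc3F)ccnc2cc1OCCCN1CCC(C)CC1` is reached from compound 3 by hydrogen in place of methyl on an aromatic carbon. Among the measured compounds shown here, none of the measured steps bears directly on this change; the only measured single step, from compound 1 to compound 2, concerns the other end of the molecule and is within the scatter. For the measured compounds named here, the only guide is that compound 4 will carry the phenyl that compound 2 carries, and compound 2 gives 220 nM, while compound 3 gives 770 nM. Compound 4 is therefore expected to give 400 nM in this assay, in the range 180 nM to 900 nM, a step of a 1.9-fold lower number from compound 3 to compound 4 (0.28 log units; within the scatter) that is expected to be toward lower numbers but is uncertain in size.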

Compound 4, half-maximal inhibitory concentration: 170 nM
Compound 4: the middle estimate sits 2.4-fold (0.37 log units) above what was measured; the whole stated range lies above it.
By their numbers in this assay, from the lowest: compounds 1, 4 and 2 (each within the scatter of the next); then compound 3.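

In this assay, among these compounds, going from 2-methylphenyl to phenyl gives a 4.5-fold lower number from compound 3 to compound 4 (0.66 log units; beyond the scatter) and so is a change beyond the scatter, which places a clear dependence of the number on the methyl ortho to a large group, something no earlier single step could show. The changes in the saturated amine ring behave differently: a 1.3-fold lower number from compound 2 to compound 4 (0.11 log units; within the scatter) for the added ring methyl and a 1.1-fold higher number from compound 1 to compound 4 (0.03 log units; within the scatter) for the exchange of ring are both within the scatter, so pyrrolidin-1-yl, piperidin-1-yl and 4-methylpiperidin-1-yl cannot be told apart here. Nothing available explains the effect of the methyl.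

Still open, going by these compounds, is whether a chlorine atom or an ethyl group at this place would match the methyl or the hydrogen. Also open, on these data alone, is whether the same methyl step holds with pyrrolidin-1-yl on the chain.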